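The source may report more compounds than this note shows. Statements on the series, on what has been measured and on what is new or still open speak of the compounds shown alone.

Measured compounds:
- compound 1 `COC(=O)/C(=C/c1ccccc1)CN1C(=O)[C@@H](OC)[C@H]1c1ccc(Cl)cc1`: 15300 nM
- compound 2 `COC(=O)/C(=C/c1ccccc1)CN1C(=O)[C@@H](OC)[C@H]1c1cccc(F)c1`: 13700 nM

Within the data shown here, in a functional assay on MCF7 cells (Homo sapiens) for antiproliferative activity, read by MTT assay, with a stated time of 48 h (on this read-out higher numbers stand for weaker inhibition and lower numbers for stronger inhibition), compound 1 stands at the higher of the two numbers, but the only measured step, a 1.1-fold lower number from compound 1 to compound 2 (0.05 log units; within the scatter), lies within the scatter, so the two values are not distinguished. Compound 3 `COC(=O)/C(=C/c1ccccc1)CN1C(=O)[C@@H](OC)[C@H]1c1cccc([N+](=O)[O-])c1` differs from compound 1 by 3-nitrophenyl in place of 4-chlorophenyl on a saturated ring carbon. Among the measured compounds shown here, the one step that bears on this is the one from compound 1 to compound 2, an exchange of the aryl group on the same saturated ring carbon, and it moved nothing beyond the scatter. Compound 3 is therefore expected to show no step beyond the scatter, a 1.0-fold lower number from compound 1 to compound 3 (0.01 log units; within the scatter), with an estimate of 15000 nM and a range from 6000 nM to 40000 nM.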

Compound 3, half-maximal inhibitory concentration: 15000 nM
Estimate against measurement, compound 3: no gap at the digits printed; low and high end bracket the measured number.
By their numbers in this assay, from the lowest: compounds 2, 3 and 1 (each within the scatter of the next).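

In this assay, the exchange at the saturated ring carbon gives a 1.0-fold lower number from compound 1 to compound 3 (0.01 log units; within the scatter) and the exchange on the aromatic carbon gives a 1.1-fold higher number from compound 2 to compound 3 (0.04 log units; within the scatter). The 3-nitrophenyl group thus adds a group with hydrogen-bond acceptors to this position, and compounds 1, 2 and 3 remain undistinguished. No measured data accompany these values to explain this result. Still open, from the compounds shown here alone, is whether an amine or a carboxylic acid on the phenyl ring would move the number beyond the scatter. Also open, going by these compounds, is what a longer alkyl chain in place of the aryl group would do.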